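A few compounds are considered here, and "the series" means these few. Any claim that something is new, unique, unknown or untested is made for them only; others in the source may bear on it.

Compound 1 `Cc1nc(S(C)(=O)=O)ccc1Oc1ncnc(OC2CCN(C(=O)OC(C)F)CC2)c1F` gives 315 nM.
Compound 2 `Cc1nc(S(C)(=O)=O)ccc1Oc1ncnc(OC2CCN(C(=O)SC3CCC3)CC2)c1F` gives 77.4 nM.
Compound 3 `Cc1nc(S(C)(=O)=O)ccc1Oc1ncnc(OC2CCN(C(=S)OC(C)C)CC2)c1F` gives 1050 nM.

All three share one core and differ only in the group on the amine nitrogen in a ring. In a functional assay on isolated protein for inhibition of Glucose-dependent insulinotropic receptor (Rattus norvegicus), read by HTRF and cAMP accumulation (a higher number here means that more compound is needed for the effect, a lower number that less compound is needed), compound 3 stands highest of the three, so it is the weakest of the set: the measured steps run a 3.3-fold higher number from compound 1 to compound 3 (0.52 log units; beyond the scatter) and a 14-fold higher number from compound 2 to compound 3 (1.13 log units; beyond the scatter). Compound 4 `CCC(F)(F)C(=O)N1CCC(Oc2ncnc(Oc3ccc(S(C)(=O)=O)nc3C)c2F)CC1` carries a group of 7 heavy atoms (4 carbon, 1 oxygen, 2 fluorine; no ring) in place of a group of 6 heavy atoms (4 carbon, 1 oxygen, 1 sulfur; no ring), on an amine nitrogen in a ring. Both steps into compound 3 show that exchanging this group shifts the number well beyond the scatter, and since compound 3 is the weakest member, leaving its group is expected to bring a lower number. The step is expected to be a 5.3-fold lower number from compound 3 to compound 4 (0.72 log units; beyond the scatter). Compound 4 is therefore estimated at about 200 nM, with a range from 60 nM to 700 nM.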

Compound 4, half-maximal effective concentration: 69.2 nM
Estimate against measurement, compound 4: 2.9-fold (0.46 log units) above; the range from low to high includes it.
By their numbers in this assay, from the lowest: compounds 4 and 2 (each within the scatter of the next); then compound 1; then compound 3.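

In this assay, 1,1-difluoropropyl on the carbonyl carbon shows that a low number at this position on the ring nitrogen does not depend on the oxygen or sulfur carried by the earlier groups: the change gives a 15-fold lower number from compound 3 to compound 4 (1.18 log units; beyond the scatter) and a 4.6-fold lower number from compound 1 to compound 4 (0.66 log units; beyond the scatter). Against cyclobutylsulfanyl it gives a 1.1-fold lower number from compound 2 to compound 4 (0.05 log units; within the scatter), so two quite different groups cannot be told apart here. Going by these compounds, what remains open is how an amine on the carbonyl carbon, or a longer fluorinated carbon chain there, would fare. Nothing shown here explains these differences.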